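Two Methylpyrazole Isomers Compared for Maximal Response

The compounds below may be only part of what the source reports. "The series", "measured", "known", "first", "only" and "open" are said of these compounds alone.

compound 1 `Cc1nc(-c2ccccc2NCC2=NCCN2)n(C)n1`: 98%
compound 2 `Cn1cc(-c2ccccc2NCC2=NCCN2)cn1`: 39%

In a functional assay with Alpha-1A adrenergic receptor (Homo sapiens) as the target, read by calcium flux (a lower number here means a smaller maximal response, a higher number a larger maximal response), compound 1 gives 98%, while compound 2 gives 39%, the lowest of the two numbers and well beyond the scatter below compound 1. Compound 3 `Cn1nccc1-c1ccccc1NCC1=NCCN1` has not yet been measured in this assay. It differs from compound 2 in a single place: 1-methyl-1H-pyrazol-5-yl in place of 1-methyl-1H-pyrazol-4-yl on an aromatic carbon. Among the compounds with values here, no step between two measured compounds that differ in only one place is available, so the size of this change cannot be read directly from the data; the expectation rests instead on the wide spread between compound 1 and compound 2. Compound 3 is expected to give 72%, within 45% to 100%, because compound 1 with a different five-membered ring on the same aromatic carbon reaches 98%. This corresponds to an expected rise of a number 33 percentage points higher from compound 2 to compound 3 (beyond the scatter), beyond the usual scatter.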

Compound 3, largest response reached (reported as maximal response), in percent of the reference or control that the assay uses: 108%
The estimate for compound 3 lay 36 percentage points below the measured number; the whole stated range lies below it.
By their numbers in this assay, from the lowest: compound 2; then compounds 1 and 3 (each within the scatter of the next).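

In this assay, within the data shown here, the same 1-methylpyrazole attached through a different ring carbon gives a number 69 percentage points higher from compound 2 to compound 3 (beyond the scatter), the only step here between two measured compounds that differ in one place. At this aromatic carbon, ortho to a group of 7 heavy atoms, the maximal response therefore depends strongly on which isomer is attached, even though the heavy atoms, hydrogen-bond donors and acceptors and net charge of the two groups count the same. Nothing available explains why the two isomers differ so widely.

The compounds shown leave open whether the high response of compound 3 would hold if an ethyl group replaced the methyl of the 1-methyl-1H-pyrazol-5-yl group. They also leave open how a phenyl or a pyridine ring at this aromatic carbon would compare.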